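Ring-closing the urea on a stilbene: expectation for compound 4

The compounds below may be only part of what the source reports. "The series", "measured", "known", "first", "only" and "open" are said of these compounds alone.

Measured compounds:
compound 1, `CCNC(=O)Nc1ccc(/C=C\c2cccc(Cl)c2)cc1`, 31000 nM
compound 2, `CCNC(=O)Nc1ccc(/C=C\c2cc(OC)c(OC)c(OC)c2)cc1`, 29000 nM
compound 3, `COc1cc(/C=C\c2ccc(N3CCNC3=O)cc2)cc(OC)c1OC`, 2.3 nM

In a functional assay on HT-1080 cells (Homo sapiens) for inhibition, read by sulforhodamine B assay, with a stated time of 48 h (a lower number here means a stronger inhibitor, a higher number a weaker inhibitor), compound 1 and compound 2 give numbers that lie within the scatter of each other. Compound 3 stands apart: the change 2-oxoimidazolidin-1-yl in place of (ethylcarbamoyl)amino on an aromatic carbon gave a 13000-fold lower number from compound 2 to compound 3 (4.10 log units; beyond the scatter). The difference between the core of compound 1 and the core of compound 2 is not broken down here. Compound 4, `O=C1NCCN1c1ccc(/C=C\c2cccc(Cl)c2)cc1`, carries the same kind of change, (2-oxoimidazolidin-1-yl in place of (ethylcarbamoyl)amino on an aromatic carbon), where the place differs only in that the group across the ring is described as a group of 9 heavy atoms rather than a large group. Because compound 1 sits at 31000 nM and the matching change gave a 13000-fold lower number from compound 2 to compound 3 (4.10 log units; beyond the scatter), a large step is expected for compound 4, though a more cautious one, since the cores differ. The expected step is a 100-fold lower number from compound 1 to compound 4 (2.01 log units; beyond the scatter), giving an estimate for compound 4 of 300 nM, between 15 nM and 6000 nM.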

Compound 4, half-maximal inhibitory concentration: 35 nM
For compound 4 the middle estimate is 8.6-fold (0.93 log units) above the measured one; low and high end bracket the measured number.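

Closing the urea into the 2-oxoimidazolidin-1-yl ring also worked on the core of compound 1: in this assay the change gave an 890-fold lower number from compound 1 to compound 4 (2.95 log units; beyond the scatter) on this core. The direction held on both cores, but the size did not carry over unchanged: the same change on two cores in this assay, a 13000-fold lower number (4.10 log units; beyond the scatter) from compound 2 to compound 3 and an 890-fold lower number (2.95 log units; beyond the scatter) from compound 1 to compound 4, 14-fold (1.15 log units) apart, beyond the scatter of two such steps. These two pairs show that the change can be carried between these two cores with a large step each time, but they do not show how large it would be on any further core.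

Which part of the difference between the two cores goes with the gap between the steps remains open. So does whether a thiourea or an acetamide in place of 2-oxoimidazolidin-1-yl would give a step of similar size.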